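The compounds below may be only part of what the source reports. "The series", "measured", "known", "first", "only" and "open" are said of these compounds alone.

In a functional assay on HT-29 cells (Homo sapiens) for antiproliferative activity, read by sulforhodamine B assay, with a stated time of 48 h (a lower number here means a stronger inhibitor, a higher number a weaker inhibitor), compound 1 `Cc1ccc(NS(=O)(=O)c2ccc(N3CCNC3=O)cc2)cc1` gives 480 nM and compound 2 `O=C1NCCN1c1ccc(S(=O)(=O)Nc2ccc(F)cc2)cc1` gives 370 nM with the two values within the scatter of each other. Compound 3 `O=C1NCCN1c1ccc(S(=O)(=O)Nc2ccc(I)cc2)cc1` differs from compound 2 by iodo in place of fluoro on an aromatic carbon with iodo in place of fluoro on an aromatic carbon. Going by the values given here, the one measured step at this place is a 1.3-fold lower number from compound 1 to compound 2 (0.11 log units; within the scatter) with fluoro in place of methyl, and it stays within the scatter, so no step beyond the scatter is expected in this assay in either direction. The estimated step is a 1.1-fold lower number from compound 2 to compound 3 (0.02 log units; within the scatter) on this reasoning. Compound 3 is estimated at 350 nM with an expected range from 140 nM to 880 nM in this measurement.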

Compound 3, half-maximal inhibitory concentration: 650 nM
Compound 3: middle estimate off by 1.9-fold (0.27 log units), on the low side; the range from low to high includes it.
By their numbers in this assay, from the lowest: compounds 2, 1 and 3 (each within the scatter of the next).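

Against fluoro, iodo on this aromatic carbon gives a 1.8-fold higher number from compound 2 to compound 3 (0.24 log units; within the scatter) in this assay, and against methyl it gives a 1.4-fold higher number from compound 1 to compound 3 (0.13 log units; within the scatter) in the same measurement. Going by these compounds alone, compound 1, compound 2 and compound 3 therefore stay within the scatter of one another, so this position tolerates an iodine atom as well as fluoro and methyl, with no step yet beyond the scatter. Nothing further is available to explain this result. Going by these compounds, whether an amine, a carboxylic acid or a longer chain at this position would hold the value remains open. So does whether any change here can move the number beyond the scatter.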